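Methyl on the ring amide nitrogen of compound 1

A few compounds are considered here, and "the series" means these few. Any claim that something is new, unique, unknown or untested is made for them only; others in the source may bear on it.

Values from a functional assay on SW480 cells (Homo sapiens) for antiproliferative activity, read by CCK-8 assay, with a stated time of 72 h (on this read-out higher numbers stand for weaker inhibition and lower numbers for stronger inhibition), follow
compound 1 (`Cc1ccc(-n2nc3c(=O)n(CCCC(=O)NCCCCCCCCNc4cccc5c4C(=O)N(C4CCC(=O)NC4=O)C5=O)nc(C)c3c2C)cc1`) gives 8000 nM
compound 2 (`Cc1ccc(-n2nc3c(=O)n(CCCC(=O)NCCCOCCOCCOCCCNc4cccc5c4C(=O)N(C4CCC(=O)NC4=O)C5=O)nc(C)c3c2C)cc1`) gives 26000 nM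
compound 3 (`Cc1ccc(-n2nc3c(=O)n(CCCC(=O)NCCCCNc4cccc5c4C(=O)N(C4CCC(=O)NC4=O)C5=O)nc(C)c3c2C)cc1`) gives 76000 nM

Compound 1 holds the lowest of the three numbers, with compound 2 the nearest and compound 3 the furthest, both beyond the scatter from it. All three share the unmethylated 2,6-dioxopiperidin-3-yl group and differ in the chain.

Compound 4 (`Cc1ccc(-n2nc3c(=O)n(CCCC(=O)NCCCCCCCCNc4cccc5c4C(=O)N(C4CCC(=O)N(C)C4=O)C5=O)nc(C)c3c2C)cc1`) keeps the chain of compound 1 and changes one place, 2,6-dioxopiperidin-3-yl to 1-methyl-2,6-dioxopiperidin-3-yl (methyl in place of hydrogen on an amide-type nitrogen in a ring), with methyl in place of hydrogen on an amide-type nitrogen in a ring. Among the measured compounds shown here, no measured compound carries this methyl, so the data hold no direct precedent. In this assay a move towards a higher number, beyond the scatter, is expected, since compound 1 (8000 nM) already holds the lowest number and compound 3 (76000 nM) shows how far the series can rise. The expected change is a 3.8-fold higher number from compound 1 to compound 4 (0.57 log units; beyond the scatter) (an estimate with a wide range). The estimated value for compound 4 is 30000 nM (range 10000 nM to 100000 nM).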

Compound 4, half-maximal inhibitory concentration: 70000 nM
Compound 4: middle estimate off by 2.3-fold (0.37 log units), on the low side; the range from low to high includes it.
By their numbers in this assay, from the lowest: compound 1; then compound 2; then compounds 4 and 3 (each within the scatter of the next).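

Methyl in place of hydrogen on an amide-type nitrogen in a ring, with the chain unchanged, gives an 8.8-fold higher number from compound 1 to compound 4 (0.94 log units; beyond the scatter) in this assay. Among the compounds shown here, the earlier compounds differ only in the chain, so this is the first reading at this position, and it shows that the change from 2,6-dioxopiperidin-3-yl to 1-methyl-2,6-dioxopiperidin-3-yl alone moves the number beyond the scatter, towards weaker inhibition. Nothing at hand accounts for this rise.

Going by these compounds, whether the same methyl has a step of similar size on the chains of compound 2 and compound 3 remains open. Also open, on these data alone, is how an ethyl group or a hydroxymethyl group on the same nitrogen would read in this assay.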